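Swapping the chain for a fluorophenyl on compound 3

This account rests on a few compounds, and the source may have more. Where it says the series, first, only, none or still open, it means among the compounds named here.

Three compounds have so far been measured in a functional assay on NCI-H1975 cells (Homo sapiens) for inhibition, read by sulforhodamine B assay, tested at 10 uM; on this read-out higher numbers stand for more inhibition at the one concentration tested (going by the name of the read-out) and lower numbers for less inhibition:

compound 1 `CN1CCN(c2ccc(C3=NN(C(=O)CCCl)C(c4ccc(N(C)C)cc4)C3)cc2)CC1` gives -0.2%
compound 2 `CN1CCN(c2ccc(C3=NN(C(=O)c4ccc(F)cc4)C(c4ccc(N(C)C)cc4)C3)cc2)CC1` gives 32.2%
compound 3 `CN(C)c1ccc(C2CC(c3ccc(-n4cncn4)cc3)=NN2C(=O)CCCl)cc1` gives -0.7%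

Compound 3 has the lowest of the three numbers; compound 1 sits within the scatter of it, while compound 2 lies beyond the scatter above it. Compound 4 `CN(C)c1ccc(C2CC(c3ccc(-n4cncn4)cc3)=NN2C(=O)c2ccc(F)cc2)cc1` differs from compound 3 by a single change: 4-fluorophenyl in place of 2-chloroethyl on a carbonyl carbon. Among the measured compounds shown here, the one measured step that bears on this change is the matching one on the other core, a number 32.4 percentage points higher from compound 1 to compound 2 (beyond the scatter), a large rise. The step of a number 0.5 percentage points lower from compound 1 to compound 3 (within the scatter) shows that both cores give the same number while the 2-chloroethyl chain is in place, so a rise of similar size in this assay is expected here. Compound 4 is therefore estimated to give 31%, between 14% and 46%, which means an expected step of a number 31.7 percentage points higher from compound 3 to compound 4 (beyond the scatter).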

Compound 4, a percentage reported as inhibition, at one concentration (the size of the read-out at that concentration, not a potency): -1.1%
For compound 4 the middle estimate is 32.1 percentage points above the measured one, and the stated range ends above it.
By their numbers in this assay, from the lowest: compounds 4, 3 and 1 (each within the scatter of the next); then compound 2.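

In this assay, 4-fluorophenyl in place of 2-chloroethyl gives a number 0.4 percentage points lower from compound 3 to compound 4 (within the scatter), so this change on the carbonyl carbon raises the number only on the core carrying 4-methylpiperazin-1-yl: the same change on two cores in this assay, a number 32.4 percentage points higher (beyond the scatter) from compound 1 to compound 2 and a number 0.4 percentage points lower (within the scatter) from compound 3 to compound 4, 32.8 percentage points apart, beyond the scatter of two such steps.
Read the other way, 1H-1,2,4-triazol-1-yl in place of 4-methylpiperazin-1-yl gives a number 33.3 percentage points lower from compound 2 to compound 4 (beyond the scatter), yet the same swap made no difference beyond the scatter with 2-chloroethyl in place: the same change on two cores in this assay, a number 0.5 percentage points lower (within the scatter) from compound 1 to compound 3 and a number 33.3 percentage points lower (beyond the scatter) from compound 2 to compound 4, 32.8 percentage points apart, beyond the scatter of two such steps.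
The two groups therefore act only in combination, and compound 2 alone carries both.

Still open, from the compounds shown here alone, is whether a morpholin-4-yl group could stand in for 4-methylpiperazin-1-yl alongside 4-fluorophenyl. Also open, going by these compounds, is whether a plain phenyl would serve on the carbonyl carbon.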